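Stretching the Acyl Chain Toward an Aromatic Ring

The source may report more compounds than this note shows. Statements on the series, on what has been measured and on what is new or still open speak of the compounds shown alone.

Compound 1, `CC(C)CCC(=O)N[C@@H](C(=O)N1CCC(c2ccc(Cl)cc2)CC1)C(C)C`, gives 26 nM in an assay on THP-1 cells for displacement of a labelled ligand from C-C chemokine receptor type 1 (Homo sapiens); a lower number here means a stronger inhibitor, a higher number a weaker inhibitor.
Compound 2, `CC(C)[C@@H](NC(=O)c1nc2ccccc2s1)C(=O)N1CCC(c2ccc(Cl)cc2)CC1`, gives 18 nM in this assay.
Compound 3, `CC(C)CC(=O)N[C@@H](C(=O)N1CCC(c2ccc(Cl)cc2)CC1)C(C)C`, gives 32 nM in this assay.

All three share one core and differ only in the group on the amide carbonyl. The number for compound 3 is not separated beyond the scatter from either neighbour: a 1.2-fold higher number from compound 1 to compound 3 (0.09 log units; within the scatter) and a 1.8-fold higher number from compound 2 to compound 3 (0.25 log units; within the scatter) are both small. Compound 4, `Cc1ccc(CCC(=O)N[C@@H](C(=O)N2CCC(c3ccc(Cl)cc3)CC2)C(C)C)cc1`, carries the change (4-methylbenzyl in place of isopropyl on a saturated chain carbon bound to a carbonyl carbon). Two earlier steps bear on this. Shortening the chain, a 1.2-fold higher number from compound 1 to compound 3 (0.09 log units; within the scatter), did nothing beyond the scatter, and swapping an alkyl chain for an aromatic ring on the carbonyl carbon, a 1.4-fold lower number from compound 1 to compound 2 (0.16 log units; within the scatter), also stayed within it. Adding a 4-methylbenzyl therefore looks like a change this position tolerates, so no step beyond the scatter is expected in this assay. The expected step is a 1.3-fold lower number from compound 3 to compound 4 (0.11 log units; within the scatter), an estimate that rests on the flat steps just named. Compound 4 is estimated at 25 nM, with a range from 8 nM to 80 nM.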

Compound 4, half-maximal inhibitory concentration: 105 nM
Estimate against measurement, compound 4: 4.2-fold (0.62 log units) below, outside the stated range (above it).
By their numbers in this assay, from the lowest: compounds 2, 1 and 3 (each within the scatter of the next); then compound 4.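

Going by these compounds alone, the flat steps among the earlier compounds did not extend to every group at this position: in this assay the change to 4-methylbenzyl gives a 3.3-fold higher number from compound 3 to compound 4 (0.52 log units; beyond the scatter) and is the first change in this set to pass beyond the scatter. The other two comparisons agree, with a 4.0-fold higher number from compound 1 to compound 4 (0.61 log units; beyond the scatter) and with a 5.8-fold higher number from compound 2 to compound 4 (0.77 log units; beyond the scatter) as the largest step in the set. An aromatic ring directly on the carbonyl carbon, as in compound 2, therefore stays close to the alkyl chains, whereas the ring carried on the saturated chain in compound 4 does not, although nothing shown accounts for this difference.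

Still open, going by these compounds, is whether the step belongs to the ring or to its methyl, which a plain phenyl on the same chain would separate. A longer alkyl chain without a ring, or an amine at the end of the chain, would show whether length alone matters.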